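This account rests on a few compounds, and the source may have more. Where it says the series, first, only, none or still open, it means among the compounds named here.

The measured compounds and their results in a functional assay on cells for agonist activity at C-X-C chemokine receptor type 4 (Homo sapiens), read by fluorescence and calcium flux, with a stated time of 90 s; on this read-out higher numbers stand for an effect only at larger amounts of compound and lower numbers for an effect already at smaller amounts:

compound 1, `c1ccc(CN(CCCCN(C[C@H]2Cc3ccccc3CN2)[C@H]2CCCc3cccnc32)Cc2ccccn2)nc1`: > 30000 nM.
compound 2, `c1ccc2c(c1)CN[C@@H](CN(CCCCN(Cc1ccncc1)Cc1ccncc1)[C@H]1CCCc3cccnc31)C2`: > 30000 nM.
compound 3, `c1ccc2c(c1)CN[C@@H](CN(CCCCNCc1ccncc1)[C@H]1CCCc3cccnc31)C2`: > 30000 nM.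

Each of these three results is a limit of the assay and not a number. Compound 1 has the value > 30000 nM, a limit of the assay and not a number. Compound 2 has the value > 30000 nM, likewise a limit. Compound 3 has the value > 30000 nM, again a limit. Among the compounds with values here, the one single-point step among them, a step that the two limits leave unreadable from compound 2 to compound 3, therefore cannot be read in size or direction. Compound 3 thus stands at the limit shared by every result shown, as summarised in the limit of > 30000 nM in this assay, at which 3 of the 3 values shown sit.

The next compound is compound 4, `c1ccc2c(c1)CN[C@@H](CN(CCCCNCC1CCCCC1)[C@H]1CCCc3cccnc31)C2`. Compared with compound 3 the change is cyclohexyl in place of pyridin-4-yl on a saturated chain carbon bound to an amine nitrogen. Within the data shown here, no measured step bears directly on this exchange; the only step known, from compound 2 to compound 3, is itself unreadable, and every result sits at the limit. Nothing in the data points to a move away from that limit, so no step beyond the scatter is expected in this assay, and the estimated step that the limit leaves unreadable from compound 3 to compound 4 is expected to be small. Compound 4 is therefore estimated at 40000 nM, in the range 8000 nM to 200000 nM, most probably again reported only as a limit.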

Compound 4, half-maximal effective concentration: > 30000 nM
Compound 4: no number, only a limit (the forecaster's own chance of this, stated with the estimate: 80%); the middle value does not contradict the limit.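

Compound 4 gives > 30000 nM in this assay, a limit of the assay and not a number. The step from compound 3 to compound 4 therefore cannot be read in size or direction, and the picture is unchanged: the limit of > 30000 nM in this assay, at which 4 of the 4 values shown sit. The compounds shown leave open whether any change to the shared core yields a measurable value in this assay.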